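This account rests on a few compounds, and the source may have more. Where it says the series, first, only, none or still open, it means among the compounds named here.

Measured compounds in an ADME assay on MRC5 cells (Homo sapiens), read by MTT assay, with a stated time of 72 h; on this read-out higher numbers stand for weaker inhibition and lower numbers for stronger inhibition:
Compound 1, `C#Cc1cn([C@@H]2O[C@H](CO)[C@@H](O)[C@H]2O)c2ncnc(OC)c12`: the assay reports only its limit, > 100000 nM.
Compound 2, `COc1ncnc2c1c(-c1cccs1)cn2[C@@H]1O[C@H](CO)[C@@H](O)[C@H]1O`: 43200 nM.
Compound 3, `COc1nc(N)nc2c1c(-c1ccccc1)cn2[C@@H]1O[C@H](CO)[C@@H](O)[C@H]1O`: the assay reports only its limit, > 100000 nM.

Compound 3 stands at the limit of this assay and has no number of its own; it is one of the two values at the limit of > 100000 nM in this assay, at which 2 of the 3 values shown sit. The step to compound 4, `COc1ncnc2c1c(-c1ccccc1)cn2[C@@H]1O[C@H](CO)[C@@H](O)[C@H]1O`, is hydrogen in place of amino on an aromatic carbon. Among the measured compounds shown here, no measured step covers the loss of an amino group. For the measured compounds named here, the only measured step, an at least 2.3-fold lower number from compound 1 to compound 2 (0.36 log units; beyond the scatter), concerns a different group elsewhere on the shared core, and it runs from a limit to a number, so it gives no guide to the direction or size of the present change. Going by the values given here, compound 2, which like compound 4 carries hydrogen at this place, is the one compound with a number in this assay, and that number is not far from the limit. Compound 4 is therefore expected to give 70000 nM in this assay, with a range from 30000 nM to 200000 nM. The expected step is an at least 1.4-fold lower number from compound 3 to compound 4 (0.15 log units; that floor lies within the scatter), with a real chance that this assay again reports only a limit for compound 4.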

Compound 4, half-maximal inhibitory concentration: > 100000 nM
Compound 4 ended at the assay's limit; the forecaster's own chance of this, stated with the estimate: 50%; at least 1.4-fold (0.15 log units) between middle value and limit.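

In this assay, phenyl in place of thiophen-2-yl on an aromatic carbon gives an at least 2.3-fold higher number from compound 2 to compound 4 (0.36 log units; beyond the scatter), so among the compounds shown, the one measured number belongs to the thiophen-2-yl compound and does not carry over to its phenyl counterpart. Hydrogen in place of amino, on the aromatic carbon between two ring nitrogen atoms, leaves the phenyl compound without a number of its own, and neither that step nor the step from compound 1 to compound 4 can be read, as limits stand on both sides. The series therefore remains largely without numbers, and only compound 2 can anchor a comparison: the limit of > 100000 nM in this assay, at which 3 of the 4 values shown sit.

From the compounds shown here alone, whether amino in place of hydrogen changes the read-out at all stays open, since a pair with a number on both sides would be needed, for instance the amino counterpart of compound 2. Also open, going by these compounds, is how a furan-2-yl or a pyridin-3-yl group would read at the place that carries thiophen-2-yl in compound 2, and whether the number seen there extends beyond that one ring.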